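Swapping the Acyl Ring of Compound 1

A few compounds are considered here, and "the series" means these few. Any claim that something is new, unique, unknown or untested is made for them only; others in the source may bear on it.

Measured in a functional assay on MCF7 cells (Homo sapiens) for antiproliferative activity, with a stated time of 5 days; on this read-out lower numbers stand for stronger inhibition and higher numbers for weaker inhibition:
- compound 1 `CCCCc1ccc2[nH]c(-c3ccc(OC)cc3)c(/C=N/NC(=O)c3ccc(OC)cc3)c2c1`: 226 nM
- compound 2 `CCCCc1ccc2[nH]c(-c3ccc(C(F)(F)F)cc3)c(/C=N/NC(=O)c3ccc(OC)cc3)c2c1`: 618 nM
- compound 3 `CCCCc1ccc2[nH]c(-c3ccc(CC)cc3)c(/C=N/NC(=O)c3cccnc3)c2c1`: 100 nM

Of these three numbers, compound 1 holds the middle place at 226 nM, with compound 3 lower at 100 nM and compound 2 higher at 618 nM. The next compound to be tested is compound 4 `CCCCc1ccc2[nH]c(-c3ccc(OC)cc3)c(/C=N/NC(=O)c3ccccn3)c2c1`, which carries pyridin-2-yl in place of 4-methoxyphenyl on a carbonyl carbon.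

Among the compounds with values here, the only measured single change is a 2.7-fold higher number from compound 1 to compound 2 (0.44 log units; beyond the scatter). That modest step bears on this change only loosely, since it leaves the (4-methoxyphenyl)carbonyl untouched. Compound 3, at 100 nM, also lacks this 4-methoxyphenyl, but it differs from compound 1 in a second place too, so it gives only a weak hint towards a lower number. A small step in this assay is therefore expected, with nothing beyond the scatter anticipated: the expected step is a 1.2-fold lower number from compound 1 to compound 4 (0.08 log units; within the scatter).

For compound 4, the estimated value is 190 nM, with an expected range of 70 nM to 520 nM.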

Compound 4, half-maximal inhibitory concentration: 160 nM
For compound 4 the middle estimate is 1.2-fold (0.07 log units) above the measured one; measured number inside the range.
By their numbers in this assay, from the lowest: compounds 3, 4 and 1 (each within the scatter of the next, the first and the last beyond it); then compound 2.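

In this assay the exchange of 4-methoxyphenyl for pyridin-2-yl on the carbonyl carbon gives a 1.4-fold lower number from compound 1 to compound 4 (0.15 log units; within the scatter) and so stays within the scatter. Within the data shown here, this is the first direct reading at this position: here, a six-membered aromatic ring with one hetero atom stands in for a carbon-only ring carrying methoxy, and compound 4 cannot be told apart from compound 1. No measurement at hand speaks to why the two compounds read alike.

From the compounds shown here alone, whether the same holds for a saturated group on this carbonyl carbon, such as piperidin-1-yl or a plain butyl chain, stays open. Also open, going by these compounds, is whether pyridin-2-yl would read the same way with the trifluoromethyl group of compound 2 in place of methoxy on the other ring.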